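This account rests on a few compounds, and the source may have more. Where it says the series, first, only, none or still open, it means among the compounds named here.

Measured compounds in this study:

Compound 1, `O[C@@H]1[C@@H](O)[C@H](Oc2cccc3cccc(S)c23)OC[C@H]1O`: 60 uM
Compound 2, `O[C@@H]1[C@@H](O)[C@H](Oc2ccc3ccc(S)cc3c2)OC[C@H]1O`: 100 uM
Compound 3, `CCCSc1cccc2cccc(O[C@@H]3OC[C@@H](O)[C@H](O)[C@H]3O)c12`: 100 uM

All three were tested in an ADME assay on HFL1 cells (Homo sapiens) for antiproliferative activity, read by crystal violet staining, with a stated time of 96 h; on this read-out higher numbers stand for an effect only at larger amounts of compound and lower numbers for an effect already at smaller amounts. Compound 3 differs from compound 1 by propyl in place of hydrogen on a sulfur, and this change gave a 1.7-fold higher number from compound 1 to compound 3 (0.22 log units; within the scatter). Compound 2 shares its atoms with compound 1 but has them joined differently; the difference between the two cores is not broken down here. In this assay compound 2 gives 100 uM, which lies level with compound 3 and within the scatter of compound 1, so no order among the three can be read from these numbers.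

Compound 4, `CCCSc1ccc2ccc(O[C@@H]3OC[C@@H](O)[C@H](O)[C@H]3O)cc2c1`, has not yet been measured. It differs from compound 2 by propyl in place of hydrogen on a sulfur, at the same kind of place as in the pair already measured, so this is the same change made a second time. For compound 4 the expected step is a 1.5-fold higher number from compound 2 to compound 4 (0.18 log units; within the scatter), which rests on the earlier step of a 1.7-fold higher number from compound 1 to compound 3 (0.22 log units; within the scatter). Compound 4 is therefore expected to give 150 uM in this assay, with a plausible range from 70 uM to 320 uM.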

Compound 4, concentration for half-maximal effect: 25 uM
Estimate against measurement, compound 4: 6.0-fold (0.78 log units) above; the whole stated range lies above it.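

In this assay, propyl in place of hydrogen on a sulfur gave a 4.0-fold lower number from compound 2 to compound 4 (0.60 log units; beyond the scatter), so the change did not carry over from one core to the other with the outcome seen on the first core: the same change on two cores in this assay, a 1.7-fold higher number (0.22 log units; within the scatter) from compound 1 to compound 3 and a 4.0-fold lower number (0.60 log units; beyond the scatter) from compound 2 to compound 4, 6.7-fold (0.82 log units) apart, beyond the scatter of two such steps. Within these two pairs, the result of this change depends on the core it is made on, and the step read on the core of compound 1 gave no reliable guide to the step on the core of compound 2. Among the compounds shown here, the data do not show which difference between the two cores lies behind this, and with only two pairs they establish no rule for any further core.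

From the compounds shown here alone, whether a shorter or longer chain on the sulfur would follow the step seen on the core of compound 2 remains open. Going by these compounds, it is equally open what an amine or a carboxylic acid at the end of such a chain would do on either core.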